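Shortening the Alkyne Chain on a Weak Uridine Analogue

The compounds below may be only part of what the source reports. "The series", "measured", "known", "first", "only" and "open" are said of these compounds alone.

Compound 2 `CCC#C[C@@]1(O)[C@@H](CO)O[C@@H](n2ccc(=O)[nH]c2=O)[C@@H]1O` carries a but-1-yn-1-yl group on a saturated ring carbon of its core. Within the data shown here, in a functional assay on KB cells (Homo sapiens), read by MTT assay (on this read-out lower numbers stand for stronger inhibition and higher numbers for weaker inhibition), compound 2 gives 226000 nM, the only plain number in this small set. Compound 1 `O=c1ccn([C@@H]2O[C@H](CO)[C@](O)(C3CC3)[C@H]2O)c(=O)[nH]1` is the related compound with cyclopropyl in that position. For compound 1 the result in this assay is only a limit of the assay, > 350000 nM. Exchanging cyclopropyl for but-1-yn-1-yl brought an at least 1.5-fold lower number from compound 1 to compound 2 (0.18 log units; that floor lies within the scatter). Compound 3 `CC#C[C@@]1(O)[C@@H](CO)O[C@@H](n2ccc(=O)[nH]c2=O)[C@@H]1O` differs from compound 2 by hydrogen in place of methyl on a saturated chain carbon bound to a triple-bonded carbon. Among the measured compounds shown here, the only measured step touches this same region but swaps a whole group, so it offers little guidance on trimming one carbon from the chain. The step from compound 2 to compound 3 is therefore expected to be small, a 1.1-fold higher number from compound 2 to compound 3 (0.04 log units; within the scatter), within the usual scatter. Compound 3 is estimated at 250000 nM, between 90000 nM and 700000 nM.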

Compound 3, half-maximal inhibitory concentration: 70800 nM
The estimate for compound 3 lay 3.5-fold (0.55 log units) above the measured number; the whole stated range lies above it.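

In this assay, hydrogen in place of methyl on a saturated chain carbon bound to a triple-bonded carbon gives a 3.2-fold lower number from compound 2 to compound 3 (0.50 log units; beyond the scatter), so trimming a single carbon from this chain can move the number beyond the scatter. Among these compounds, the comparison with cyclopropyl now shows an at least 4.9-fold lower number from compound 1 to compound 3 (0.69 log units; beyond the scatter), the first such comparison that clears the scatter. The value of compound 1, > 350000 nM, is a limit of the assay and not a number.

The link between chain length and the read-out rests on just two alkynes, so it cannot yet be called a trend. Whether ethynyl, with the chain cut back fully, or a longer chain such as pent-1-yn-1-yl would continue the same direction stays open, as does the reason for the shift.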